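Swapping the aryl cap of compound 1 for cyclopropylmethyl

A few compounds are considered here, and "the series" means these few. Any claim that something is new, unique, unknown or untested is made for them only; others in the source may bear on it.

Measured compounds:
compound 1, `CS(=O)(=O)c1ccc(-n2ccc3cnc(Nc4cnn(CCCCCCC(=O)NO)c4)nc32)cc1`, 5.9 nM
compound 2, `COc1cccc(Cn2ccc3cnc(Nc4cnn(CCCCCC(=O)NO)c4)nc32)c1`, 37.6 nM
compound 3, `O=C(CCCCCCn1cc(Nc2ncc3ccn(C4CCCC4)c3n2)cn1)NO`, 22 nM

In an assay on isolated protein for inhibition of protein deacetylase HDAC6 (Homo sapiens), with a stated time of 60 min (a higher number here means a weaker inhibitor, a lower number a stronger inhibitor), compound 1 gives 5.9 nM, the lowest of the three numbers; compound 3 sits nearest with 22 nM and compound 2 furthest with 37.6 nM. Compound 4, `O=C(CCCCCCn1cc(Nc2ncc3ccn(CC4CC4)c3n2)cn1)NO`, has not yet been measured. It differs from compound 1 in one place: cyclopropylmethyl in place of 4-(methylsulfonyl)phenyl on an aromatic nitrogen. Among the measured compounds shown here, the one measured step that bears on this is the replacement of the same aryl group by cyclopentyl, which gave a 3.7-fold higher number from compound 1 to compound 3 (0.57 log units; beyond the scatter). Compound 2 carries a different group on that aromatic nitrogen and a shorter chain, so its value only shows that other caps also give higher numbers than compound 1. A small saturated group entering in place of the aryl cap is therefore expected to raise the number to a modest degree, much as in compound 3. For compound 4 the estimate in this assay is 20 nM, within 8 nM to 50 nM. That estimate means an expected step of a 3.4-fold higher number from compound 1 to compound 4 (0.53 log units; beyond the scatter).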

Compound 4, half-maximal inhibitory concentration: 16 nM
For compound 4 the middle estimate is 1.3-fold (0.10 log units) above the measured one; measured number inside the range.
By their numbers in this assay, from the lowest: compound 1; then compounds 4, 3 and 2 (each within the scatter of the next, the first and the last beyond it).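

In this assay, a second saturated group on the aromatic nitrogen also gives a higher number than the 4-(methylsulfonyl)phenyl of compound 1, with a 2.7-fold higher number from compound 1 to compound 4 (0.43 log units; beyond the scatter), so this loss is not confined to cyclopentyl. Cyclopropylmethyl and cyclopentyl cannot be told apart at this position, with a 1.4-fold lower number from compound 3 to compound 4 (0.14 log units; within the scatter), although both differ from the aryl cap in the same direction. Nothing available gives a reason for these steps.

From the compounds shown here alone, it remains open whether the lower number of compound 1 belongs to the phenyl ring itself or to its methylsulfonyl group, which a plain phenyl or a 4-methoxyphenyl on the same nitrogen would separate. Going by these compounds, it is also open how a saturated group carrying an amine or a carboxylic acid would compare with the two carbon-only groups at this position.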